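A Chain Swap on the Amide Side Chain

The source may report more compounds than this note shows. Statements on the series, on what has been measured and on what is new or still open speak of the compounds shown alone.

Compound 1, `O=C(NCc1ccccc1)Nc1cc2nc(C3CCCCC3)[nH]c2cc1N1CCCC1`, in an ADME assay on Vero cells (Chlorocebus sabaeus) for cytotoxicity, read by resazurin assay, with a stated time of 3 days (on this read-out higher numbers stand for weaker inhibition and lower numbers for stronger inhibition), gives > 100 ug/mL, which is a limit of the assay rather than a number.
Compound 2, `O=C(CCc1ccccc1)Nc1cc2nc(C3CCCCC3)[nH]c2cc1N1CCCC1`, in this assay gives > 100 ug/mL, again a limit of the assay.
Compound 3, `CCCOCC(=O)Nc1cc2nc(C3CCCCC3)[nH]c2cc1N1CCCC1`, in this assay gives > 100 ug/mL, also a limit of the assay.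

Compound 3 therefore stands only at a limit, and so do the other two, as the limit of > 100 ug/mL in this assay, at which 3 of the 3 values shown sit, shows. The step that bears most directly on the change in hand is a step that the two limits leave unreadable from compound 2 to compound 3, since it alters the same saturated chain carbon bound to a carbonyl carbon; the steps a step that the two limits leave unreadable from compound 1 to compound 2 and a step that the two limits leave unreadable from compound 1 to compound 3 are equally unreadable. Compound 4, `CCCCCC(=O)Nc1cc2nc(C3CCCCC3)[nH]c2cc1N1CCCC1`, differs from compound 3 by butyl in place of propoxy on a saturated chain carbon bound to a carbonyl carbon. With every measured value sitting at the same limit, no size or direction of step can be read, and none beyond the scatter is expected; the estimated step is a step that the limit leaves unreadable from compound 3 to compound 4. Compound 4 is expected to give about 150 ug/mL in this assay, within 60 ug/mL to 400 ug/mL, most likely reported again as a limit.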

Compound 4, half-maximal inhibitory concentration: > 100 ug/mL
Compound 4 ended at the assay's limit (the forecaster's own chance of this, stated with the estimate: 80%); the middle value is on the limit's open side.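

No step from compound 1, compound 2 or compound 3 to compound 4 can be read, since all four compounds stop at the same limit of the assay: the limit of > 100 ug/mL in this assay, at which 4 of the 4 values shown sit.

The compounds shown leave open whether these side chains differ at all in this assay, and at what concentration any of them would inhibit.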